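Salicylaldimine series against a flavin amine oxidase

This account rests on a few compounds, and the source may have more. Where it says the series, first, only, none or still open, it means among the compounds named here.

Working notes on a small set of imines sharing a benzyloxyphenyl imine core, all tested in an assay on isolated protein for inhibition of Amine oxidase [flavin-containing] B (Homo sapiens), read by fluorescence and Amplex Red, with stated times of 15 min and 20 min; on this read-out lower numbers stand for stronger inhibition and higher numbers for weaker inhibition. Compound 1 `Oc1cc(O)c(/C=N/c2ccc(OCc3ccccc3)cc2)c(O)c1` gives 10100 nM in this assay. Compound 2 `Cc1cccc(/C=N/c2ccc(OCc3ccccc3)cc2)c1O` gives 15500 nM in this assay, the second highest of the three numbers; its nearest neighbour is compound 3 `Oc1ccc2ccccc2c1/C=N/c1ccc(OCc2ccccc2)cc1`, which gives 19200 nM in this assay, and its furthest is compound 1, both gaps lying within the usual scatter of the measurement. On these numbers the three compounds cannot be ordered against one another.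

Compound 4 `Oc1ccc(Br)cc1/C=N/c1ccc(OCc2ccccc2)cc1` is not yet measured in this assay. It differs from compound 2 by 5-bromo-2-hydroxyphenyl in place of 2-hydroxy-3-methylphenyl on a carbon with a double bond to nitrogen. Among the compounds with values here, no step between measured compounds is available to calibrate this change. All three measured analogues sit close together despite different aryl groups on the imine carbon, so the expected step of a 1.2-fold lower number from compound 2 to compound 4 (0.08 log units; within the scatter) is none beyond the scatter. Compound 4 is estimated at 13000 nM, with a plausible range from 5000 nM to 32000 nM in this assay.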

Compound 4, half-maximal inhibitory concentration: 31700 nM
For compound 4 the middle estimate is 2.4-fold (0.39 log units) below the measured one; low and high end bracket the measured number.
By their numbers in this assay, from the lowest: compounds 1, 2, 3 and 4 (each within the scatter of the next, the first and the last beyond it).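

In this assay, within the data shown here, the change to 5-bromo-2-hydroxyphenyl in place of 2-hydroxy-3-methylphenyl on a carbon with a double bond to nitrogen gives a 2.0-fold higher number from compound 2 to compound 4 (0.31 log units; beyond the scatter) and is the only step so far, modest in size but beyond the scatter. This position therefore does not tolerate every aryl group equally, even though the groups that leave and enter match in heavy-atom, donor and acceptor counts, so those counts do not account for the difference. Nothing available gives a reason for this step.

The compounds shown do not separate the effect of adding the bromine from that of losing the methyl, since both change at once. Also open, going by these compounds, is what this assay would return for an amine or a carboxylic acid in place of the bromine.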